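The compounds below may be only part of what the source reports. "The series", "measured", "known", "first", "only" and "open" are said of these compounds alone.

Compound 1 `C/N=C(/NC#N)NCCCn1nc(-c2ccccc2)ccc1=O` in a functional assay on the whole organism (stomach) with Rattus norvegicus as the target (a higher number here means that more compound is needed for the effect, a lower number that less compound is needed), gives > 100 mg/kg, which is a limit of the assay rather than a number. Compound 2 `CC/N=C(/NC#N)NCCCn1nc(C)ccc1=O` gives > 100 mg/kg, again only a limit. Compound 3 `CCC/N=C(/NC#N)NCCCn1nc(-c2ccccc2)ccc1=O` gives 100 mg/kg.

Compound 1 therefore stands at the limit it shares with compound 2, while only compound 3 carries a measured number. Among the compounds with values here, the single step between measured compounds, a number no higher from compound 1 to compound 3 (the limit leaves the size open), has a size that cannot be read because one end is a limit. Compound 4 `CC/N=C(\S)NCCCCn1nc(-c2ccccc2)ccc1=O` differs from compound 1 by a group of 7 heavy atoms (4 carbon, 2 nitrogen, 1 sulfur; no ring) in place of a group of 7 heavy atoms (3 carbon, 4 nitrogen; no ring), on a saturated chain carbon, three bonds along the chain from an aromatic nitrogen. Within the data shown here, no measured step covers a change of this kind, so the only anchor is the limit of > 100 mg/kg in this assay, at which 2 of the 3 values shown sit, and the expected step of a number no higher from compound 1 to compound 4 (the limit leaves the size open) is judged small. Compound 4 is estimated at 100 mg/kg, within a range from 30 mg/kg to 300 mg/kg, quite possibly reported again only as a limit.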

Compound 4, dose for half-maximal effect: 37.2 mg/kg
Estimate against measurement, compound 4: 2.7-fold (0.43 log units) above; the measured number falls inside the stated range.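

In this assay, replacing the group of 7 heavy atoms (3 carbon, 4 nitrogen; no ring) with the group of 7 heavy atoms (4 carbon, 2 nitrogen, 1 sulfur; no ring) gives an at least 2.6-fold lower number from compound 1 to compound 4 (0.42 log units; beyond the scatter). This is the first step shown whose size can be read at least in part, and it shows that the dose needed responds to a change at this position. The true size remains open, and limits still mark much of the set: the limit of > 100 mg/kg in this assay, at which 2 of the 4 values shown sit.

From the compounds shown here alone, whether the sulfur or the loss of the nitrile carries the step stays open. So does how an amine or a carboxylic acid would behave in this place.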